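A Methyl Removed from the Most Potent Compound

A few compounds are considered here, and "the series" means these few. Any claim that something is new, unique, unknown or untested is made for them only; others in the source may bear on it.

In a functional assay (trachea) for antagonist activity, with Cavia porcellus as the target (a higher number here means a more potent compound, by a factor of ten per unit of this negative logarithm, a lower number a less potent compound), measurements exist for compound 1, compound 2 and compound 3. Compound 2 `COc1cc(C(=O)NS(=O)(=O)c2ccccc2C)ccc1Cn1ncc2ccc(NC(=O)CC3CCCC3)cc21` stands highest among them: in this assay compound 2 gives 10.9. Its nearest neighbour is compound 1 `CCCCOC(=O)Nc1ccc2cnn(Cc3ccc(C(=O)NS(=O)(=O)c4ccccc4)cc3OC)c2c1`, which in this assay gives 9.2, a gap beyond the scatter. Furthest away is compound 3 `CCCCOC(=O)Nc1ccc2ccn(Cc3ccc(-c4nn[nH]n4)cc3OC)c2c1`, which in this assay gives 7.2, again beyond the scatter. Compound 1 and compound 3 each differ from compound 2 in more than one place. Among the compounds with values here, no single-point step between measured compounds is at hand.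

The unmeasured compound 4 `COc1cc(C(=O)NS(=O)(=O)c2ccccc2)ccc1Cn1ncc2ccc(NC(=O)CC3CCCC3)cc21` differs from compound 2 by one change: hydrogen in place of methyl on an aromatic carbon. Compound 1 also carries a phenylsulfonyl group and gives 9.2, but its other differences from compound 2 keep that number from settling the question. The step of a number 0.50 log units lower from compound 2 to compound 4 (beyond the scatter) is therefore expected to be a modest loss, possibly no larger than the scatter. Compound 4 is estimated at 10.4, with a range from 9.6 to 11.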

Compound 4, negative logarithm of the antagonist equilibrium constant: 10.5
For compound 4 the middle estimate is 0.10 log units below the measured one, within the range that was stated.
By their numbers in this assay, from the lowest: compound 3; then compound 1; then compound 4; then compound 2.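

In this assay, the change from 2-methylphenyl to phenyl can now be read on its own, and removing the methyl gives a number 0.40 log units lower from compound 2 to compound 4 (beyond the scatter), so this aromatic carbon, ortho to a large group, contributes measurably, yet compound 4 remains far above compound 1 and compound 3 without the methyl. Compound 4 also opens a second single-place comparison: cyclopentylmethyl in place of butoxy on a carbonyl carbon gives a number 1.30 log units higher from compound 1 to compound 4 (beyond the scatter), showing that the phenylsulfonyl series responds far more strongly at that carbonyl than at the methyl position. Nothing measured here explains either step.

The compounds shown leave open what an ethyl, a methoxy or a chlorine would give on this aromatic carbon. They also leave open whether adding the methyl to compound 1, with butoxy on the carbonyl carbon, would give a step of similar size.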